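From hydroxy to amino on a sensitive side chain

This account rests on a few compounds, and the source may have more. Where it says the series, first, only, none or still open, it means among the compounds named here.

In a functional assay on NCI-H460 cells (Homo sapiens) (on this read-out higher numbers stand for an effect only at larger amounts of compound and lower numbers for an effect already at smaller amounts), compound 1 `CCOC(=O)C(=O)N1N=C(c2ccc(N(C)C)cc2)OC1c1cc(OC)c(OC)c(OC)c1` gives 33 uM and compound 2 `COc1cc(C2OC(c3ccc(N(C)C)cc3)=NN2C(=O)CO)cc(OC)c1OC` gives 0.043 uM as the lower of the two numbers. Compound 2 therefore shows its effect at the smaller amount.

Compound 3 `COc1cc(C2OC(c3ccc(N(C)C)cc3)=NN2C(=O)CN)cc(OC)c1OC` has not yet been measured. It carries amino in place of hydroxy on a saturated chain carbon bound to a carbonyl carbon, and the count of that difference reads amino in place of hydroxy on a saturated chain carbon bound to a carbonyl carbon with the rest of the structure unchanged.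

For the measured compounds named here, only one measured step bears on this change. It is large, a 770-fold lower number from compound 1 to compound 2 (2.89 log units; beyond the scatter) when hydroxymethyl replaces ethoxycarbonyl on a carbonyl carbon. It shows that the numbers can move far with a change on that carbonyl carbon, yet it involves a different pair of groups. Going by the values given here, no measured pair compares hydroxy with amino, so the direction remains uncertain.

A moderate step towards a higher number is expected in this assay and is far smaller than the measured one. The expected step is a 3.5-fold higher number from compound 2 to compound 3 (0.54 log units; beyond the scatter) in this estimate. For compound 3 the estimated value is 0.15 uM with an expected range from 0.02 uM to 1.5 uM in repeat measurements.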

Compound 3, concentration for half-maximal effect: 0.66 uM
The estimate for compound 3 lay 4.4-fold (0.64 log units) below the measured number, within the range that was stated.
By their numbers in this assay, from the lowest: compound 2; then compound 3; then compound 1.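

In this assay, the exchange of hydroxy for amino on a saturated chain carbon bound to a carbonyl carbon is a large step by itself (a 15-fold higher number from compound 2 to compound 3 (1.19 log units; beyond the scatter)). The computed counts for the two groups match in heavy atoms, hydrogen-bond donors, hydrogen-bond acceptors and net charge, so those counts alone do not separate them, yet the assay clearly does. The lower number relative to the ethoxycarbonyl compound is not unique to hydroxymethyl, since aminomethyl also gives a large step in that direction (a 50-fold lower number from compound 1 to compound 3 (1.70 log units; beyond the scatter)), though it falls short of the step seen with hydroxymethyl (a 770-fold lower number from compound 1 to compound 2 (2.89 log units; beyond the scatter)).

On these data alone, with only these three compounds, it remains open how a methylamino group or a methoxy group would compare with hydroxy and amino at this place, and whether a longer chain such as hydroxyethyl would keep the low number of compound 2. Nothing measured here gives a reason for the size of the step from hydroxy to amino.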